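A Smaller Group on the Amide of Compound 2

The compounds below may be only part of what the source reports. "The series", "measured", "known", "first", "only" and "open" are said of these compounds alone.

Compound 2 `O=C(O)/C=C/C(=O)N1C/C(=C\c2ccccc2F)C(=O)/C(=C/c2ccccc2F)C1` gives 29000 nM in a functional assay on NCI-H441 cells (Homo sapiens) for antiproliferative activity, with a stated time of 24 h; on this read-out higher numbers stand for weaker inhibition and lower numbers for stronger inhibition.
Compound 1 `CN(C)c1ccc(/C=C2\CNC/C(=C\c3ccc(N(C)C)cc3)C2=O)cc1` gives 101000 nM in this assay.

Of the two compounds measured, compound 2 has the lower number, and compound 1 sits a clear distance above it, beyond the usual scatter, so compound 2 is the stronger inhibitor of the pair. Both, however, inhibit only at high concentrations.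

Compound 3 `CC(=O)N1C/C(=C\c2ccccc2F)C(=O)/C(=C/c2ccccc2F)C1` keeps the shared core of compound 2 and changes one group on a carbonyl carbon whose other neighbour is an amide-type nitrogen in a ring: methyl in place of 2-carboxyethenyl on a carbonyl carbon

Going by the values given here, no measured pair shows a change of this kind, so nothing directly guides the size of the step. Because compound 2 gives 29000 nM, only a weak inhibitor is expected either way. The step of a 1.3-fold higher number from compound 2 to compound 3 (0.12 log units; within the scatter) is expected to be small, likely within the scatter, with a slight lean toward weaker inhibition. Compound 3 is therefore estimated at 38000 nM, with a range from 12000 nM to 120000 nM.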

Compound 3, half-maximal inhibitory concentration: 54000 nM
Estimate against measurement, compound 3: 1.4-fold (0.15 log units) below; the measured number falls inside the stated range.
By their numbers in this assay, from the lowest: compounds 2, 3 and 1 (each within the scatter of the next, the first and the last beyond it).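

Swapping the 2-carboxyethenyl group for methyl on this carbonyl carbon gives a 1.9-fold higher number from compound 2 to compound 3 (0.27 log units; within the scatter) in this assay. The group that leaves has five heavy atoms and a hydrogen-bond donor, while the group that enters has one heavy atom and no donor, yet this large change in the group does not separate the two compounds on this read-out. Nothing measured alongside these numbers speaks to why the step is this small.

One step at one position cannot show whether any group placed on this carbonyl carbon would move the number beyond the scatter. A longer chain, a phenyl ring or a chain ending in an amine at the same place would test whether this position responds at all in this assay.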